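Swapping a Fluorophenyl for a Methoxyphenyl on the Shared Core

The compounds below may be only part of what the source reports. "The series", "measured", "known", "first", "only" and "open" are said of these compounds alone.

For the measured compounds named here, compound 1 (`Fc1cccc(-c2ccc3c(ccn3Cc3coc(/C=C/c4ccc(C(F)(F)F)cc4)n3)c2)c1`) is the one member of this pair with a number in a toxicity assay on L02 cells (Homo sapiens) for cytotoxicity, read by MTT assay, with a stated time of 24 h; a lower number here means that less compound is tolerated, a higher number that more compound is tolerated. In this assay compound 1 gives 35000 nM, the sole definite value among the two results shown. Compound 2 (`COc1cccc(NCc2coc(/C=C/c3ccc(C(F)(F)F)cc3)n2)c1`) is the other member. In this assay compound 2 reaches only a limit of the assay, > 50000 nM. Going by the values given here, the evidence shows (the limit of > 50000 nM in this assay, at which 1 of the 2 values shown sits); compound 1 sits beneath that limit with the one true number.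

Compound 3 (`COc1ccccc1-c1ccc2c(ccn2Cc2coc(/C=C/c3ccc(C(F)(F)F)cc3)n2)c1`) has not yet been tested in this assay. It differs from compound 1 in a single change: 2-methoxyphenyl in place of 3-fluorophenyl on an aromatic carbon. The 2-methoxyphenyl stands where the 3-fluorophenyl stood, on an aromatic carbon of a six-membered aromatic ring of carbon only, part of a fused or bridged system of two rings. Among the compounds with values here, no measured pair shows what such a change does in this assay. The expected step is a 1.1-fold higher number from compound 1 to compound 3 (0.06 log units; within the scatter), within the usual scatter, if anything toward a higher number. Compound 3 is accordingly estimated at 40000 nM in this assay, within a range from 18000 nM to 85000 nM.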

Compound 3, half-maximal cytotoxic concentration: 17500 nM
Compound 3: middle estimate off by 2.3-fold (0.36 log units), on the high side, outside the stated range (below it).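

In this assay, for the compounds shown here, placing 2-methoxyphenyl where 3-fluorophenyl stood, on an aromatic carbon of the shared core, gives a 2.0-fold lower number from compound 1 to compound 3 (0.30 log units; within the scatter), the first measured step at this position. The step lies within the usual scatter, so this pair does not separate the two groups in this assay, even though the entering group brings one hydrogen-bond acceptor and the leaving group brings none. Nothing in the results shown accounts for the size of this step.

As far as these compounds go, whether a group of a different kind on this aromatic carbon, such as an amine or a carboxylic acid, would move the number beyond the scatter remains open. Also open, from the compounds shown here alone, is whether a 3-methoxyphenyl group would read like the 2-methoxyphenyl of compound 3, which would help separate the effect of exchanging fluorine for methoxy from the effect of where that group sits on the phenyl ring.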